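Moving the chlorine from 2-chlorophenyl to 3-chlorophenyl

The compounds below may be only part of what the source reports. "The series", "measured", "known", "first", "only" and "open" are said of these compounds alone.

Measured so far in a functional assay on SGC-7901 cells (Homo sapiens) for inhibition, read by MTT assay, with a stated time of 24 h (a higher number here means a weaker inhibitor, a lower number a stronger inhibitor), here:
- compound 1 `CC1(C)[C@H]2CC[C@]1(C)N(Cc1cn(-c3ccccc3Br)nn1)C(=O)C2` gives 500 nM
- compound 2 `CC1(C)[C@H]2CC[C@]1(C)N(Cc1cn(-c3ccccc3Cl)nn1)C(=O)C2` gives 220 nM

Compound 2 at 220 nM holds the lowest of the two numbers. Among the compounds with values here, compound 3 `CC1(C)[C@H]2CC[C@]1(C)N(Cc1cn(-c3cccc(Cl)c3)nn1)C(=O)C2` awaits measurement and has 3-chlorophenyl in place of 2-chlorophenyl on an aromatic nitrogen as its only change. Within the data shown here, the one measured step of a 2.3-fold lower number from compound 1 to compound 2 (0.36 log units; beyond the scatter) is modest and exchanges a halogen on an aromatic carbon, so it bears only indirectly. Among the measured compounds shown here, no measured step moves the chlorine. In this assay a step of no greater size is expected, leaning to a higher number given that compound 2 at 220 nM is the lower value. The estimate means an expected 1.4-fold higher number from compound 2 to compound 3 (0.13 log units; within the scatter) in all. Compound 3 is thus estimated at 300 nM with between 110 nM and 800 nM as its likely range.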

Compound 3, half-maximal inhibitory concentration: 510 nM
Beside the measured number, compound 3's estimate is 1.7-fold (0.23 log units) below it; the range from low to high includes it.
By their numbers in this assay, from the lowest: compound 2; then compounds 1 and 3 (each within the scatter of the next).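

In this assay, 3-chlorophenyl in place of 2-chlorophenyl gives a 2.3-fold higher number from compound 2 to compound 3 (0.37 log units; beyond the scatter), which shows that the place of the chlorine on the phenyl ring, and not only the identity of the halogen, bears on the number. 3-Chlorophenyl in place of 2-bromophenyl gives a 1.0-fold higher number from compound 1 to compound 3 (0.01 log units; within the scatter), so compound 2 alone stands apart from the other two. No evidence available here explains the difference between the two chlorophenyl groups. The compounds shown leave open how a methoxy group or an amine in place of the chlorine would read in this assay.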